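This account rests on a few compounds, and the source may have more. Where it says the series, first, only, none or still open, it means among the compounds named here.

Measured in a functional assay on A549 cells (Homo sapiens) for cytotoxicity, read by CCK-8 assay, with a stated time of 24 h; on this read-out higher numbers stand for weaker inhibition and lower numbers for stronger inhibition:
compound 1 `C/C(=C\c1cc(-c2ccc(C)nc2)co1)C(N)=O` gives > 50000 nM
compound 2 `C/C(=C\c1cc(C2=CCCC2)co1)C(N)=O` gives 16600 nM
compound 3 `C/C(=C\c1cc(-c2ccc(C)cc2)cs1)C(N)=O` gives > 50000 nM

Compound 3 stands at the upper edge of what this assay reports: its value is a limit, not a number. The same holds for compound 1, whose value is also a limit. Only compound 2 gives a measured number in this assay, and that number lies well toward the weak end. Going by the values given here, two of the three values sit at the limit of > 50000 nM in this assay, at which 2 of the 3 values shown sit, so the series so far gives no measured step from which the size of any change can be read.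

Compound 4 `C/C(=C\c1cc(-c2ccc(C#N)cc2)cs1)C(N)=O` differs from compound 3 by cyano in place of methyl on an aromatic carbon, para to a large group. Among the compounds with values here, no step between measured compounds exists here, so no expectation of size or direction can be drawn from the series itself. The step from compound 3 to compound 4 an at least 1.1-fold lower number from compound 3 to compound 4 (0.04 log units; that floor lies within the scatter) is expected to stay within the usual scatter, with the limit remaining the most likely read-out. Compound 4 is therefore estimated at 45000 nM in this assay, with a range from 15000 nM to 150000 nM.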

Compound 4, half-maximal inhibitory concentration: > 50000 nM
Compound 4 gave a limit, no number; the forecaster's own chance of this, stated with the estimate: 60%; middle value at least 1.1-fold (0.04 log units) away from the limit.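

Compound 3 and compound 4 both give limits rather than numbers, so no step can be read for cyano in place of methyl on an aromatic carbon: the limit of > 50000 nM in this assay, at which 3 of the 4 values shown sit.

The compounds shown leave open whether this change alters the read-out at all.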